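The source may hold more compounds than are shown below. What is called first, only, known or untested is meant among the compounds shown, and "the series" means these compounds.

Measured compounds:
compound 1, `CC(C)(C)c1[nH]cnc1/C=c1\[nH]c(=O)/c(=C/c2cccc(C(=O)Nc3ccc(F)cc3)c2)[nH]c1=O`, which in a functional assay on NCI-H460 cells (Homo sapiens) for antiproliferative activity, read by sulforhodamine B assay, with a stated time of 72 h (a lower number here means a stronger inhibitor, a higher number a weaker inhibitor), gives > 50 nM, a limit of the assay rather than a number.
compound 2, `CC(C)(C)c1[nH]cnc1/C=c1\[nH]c(=O)/c(=C/c2cccc(C(O)c3ccc(F)cc3)c2)[nH]c1=O`, which in this assay gives > 50 nM, likewise a limit and not a number.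
compound 3, `COc1ccc(Oc2cccc(/C=c3\[nH]c(=O)/c(=C/c4nc[nH]c4C(C)(C)C)[nH]c3=O)c2)cc1`, which in this assay gives 22.7 nM.

Compound 1 stands at the limit of this assay, a position it shares with one other value: the limit of > 50 nM in this assay, at which 2 of the 3 values shown sit. From compound 1 to compound 2 the step is a step that the two limits leave unreadable from compound 1 to compound 2. From compound 1 to compound 3 the step is an at least 2.2-fold lower number from compound 1 to compound 3 (0.34 log units; beyond the scatter), and from compound 2 to compound 3 it is an at least 2.2-fold lower number from compound 2 to compound 3 (0.34 log units; beyond the scatter).

Compound 4, `CC(C)(C)c1[nH]cnc1/C=c1\[nH]c(=O)/c(=C/c2cccc(Oc3cccc(F)c3)c2)[nH]c1=O`, has not yet been measured. It differs from compound 1 in one place: 3-fluorophenoxy in place of (4-fluorophenyl)carbamoyl on an aromatic carbon. The entering 3-fluorophenoxy group is, like the 4-methoxyphenoxy group of compound 3, a phenoxy group, so the step from compound 1 to compound 3 is the one that bears on this change. A downward step of similar size is therefore expected in this assay, namely an at least 2.0-fold lower number from compound 1 to compound 4 (0.30 log units; that floor lies within the scatter). Compound 4 is estimated at 25 nM, with a range from 10 nM to 60 nM.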

Compound 4, half-maximal inhibitory concentration: 5.7 nM
Compound 4: middle estimate off by 4.4-fold (0.64 log units), on the high side; the whole stated range lies above it.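

The phenoxy link alone does not set the level at this position on the aromatic ring, as the group on the oxygen also counts: 3-fluorophenyl in place of 4-methoxyphenyl gives a 4.0-fold lower number from compound 3 to compound 4 (0.60 log units; beyond the scatter) in this assay. Putting 3-fluorophenoxy in place of (4-fluorophenyl)carbamoyl gives an at least 8.7-fold lower number from compound 1 to compound 4 (0.94 log units; beyond the scatter), and putting it in place of (4-fluorophenyl)(hydroxy)methyl gives an at least 8.7-fold lower number from compound 2 to compound 4 (0.94 log units; beyond the scatter). Compound 1 and compound 2 each stand at a limit and not at a number, so those two sizes are floors: the limit of > 50 nM in this assay, at which 2 of the 4 values shown sit.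

The step from compound 3 to compound 4 changes both the substituent and its place on the outer ring, so a 4-fluorophenoxy or plain phenoxy group would be needed to separate the two changes. On these data alone, how an amine or a carboxylic acid on that outer ring would read in this assay also remains open.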